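The source may report more compounds than this note shows. Statements on the series, on what has been measured and on what is new or still open speak of the compounds shown alone.

Measured so far:
compound 1, `Nc1scc(CN2CCN(c3ccc(Cl)cc3F)CC2)c1C(=O)c1ccc(Cl)cc1`: -81%
compound 2, `Nc1scc(CN2CCN(c3cccc(F)c3)CC2)c1C(=O)c1cccc(C(F)(F)F)c1`: -62%

In a functional assay on CHO cells with adenosine receptor A1 (Homo sapiens) as the target, read by cAMP accumulation and immunoassay, with a stated time of 6 min, tested at 10 uM (a higher number here means a weaker effect of the compound at the concentration tested, a lower number a stronger effect), compound 1 gives -81%, and compound 2 gives -62%. Compound 2 thus stands highest of the two numbers, its nearest neighbour being compound 1, a number lower by a gap that lies beyond the usual scatter. Going by the values given here, no step between compounds that differ in one place is available, so the two values show only that compound 1 acts more strongly than compound 2 at this concentration.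

The next compound is compound 3, `Nc1scc(CN2CCN(c3cccc(F)c3)CC2)c1C(=O)c1ccc(Cl)cc1`. It differs from compound 2 in one place: 4-chlorophenyl in place of 3-(trifluoromethyl)phenyl on a carbonyl carbon.

Compound 3 carries the same group on its carbonyl carbon as compound 1, so the step from compound 2 to compound 3 in this assay is expected to run downward, toward a stronger effect, by a modest amount that may or may not exceed the scatter, a number 10 percentage points lower from compound 2 to compound 3 (within the scatter). For compound 3 in this assay the estimated value is -72%, expected to fall between -90% and -52%.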

Compound 3, a percentage reported as activity, at one concentration (the size of the read-out at that concentration, not a potency): -82%
Compound 3: the middle estimate sits 10 percentage points above what was measured; the measured number falls inside the stated range.
By their numbers in this assay, from the lowest: compounds 3 and 1 (each within the scatter of the next); then compound 2.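

In this assay, the carbonyl carbon now has a direct comparison: 4-chlorophenyl in place of 3-(trifluoromethyl)phenyl gives a number 20 percentage points lower from compound 2 to compound 3 (beyond the scatter), so this single exchange moves the read-out toward a stronger effect. On the amine nitrogen in a ring, 3-fluorophenyl in place of 4-chloro-2-fluorophenyl gives a number 1 percentage points lower from compound 1 to compound 3 (within the scatter), so with 4-chlorophenyl on the carbonyl carbon, this assay does not tell these two groups apart. No measurement offered here gives a cause for either step.

As far as these compounds go, the exchange on the carbonyl carbon has been read only with 3-fluorophenyl on the amine nitrogen in a ring, so whether it carries over to 4-chloro-2-fluorophenyl there stays open. Also open, from the compounds shown here alone, is how the read-out would respond to an unsubstituted phenyl or a pyridine ring on the carbonyl carbon.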